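Swapping the carboxy group of compound 2

This account rests on a few compounds, and the source may have more. Where it says the series, first, only, none or still open, it means among the compounds named here.

Measured in a functional assay on PC-3 cells (Homo sapiens) for antiproliferative activity, with a stated time of 72 h; on this read-out lower numbers stand for stronger inhibition and higher numbers for weaker inhibition:
- Compound 1 `COc1cc(OC)c(C(=O)/C=C/c2ccccc2Cl)c(O)c1CN1CCCCC1`: 1700 nM
- Compound 2 `COc1cc(OC)c(C(=O)/C=C/c2ccccc2Cl)c(O)c1CN(C)CC(=O)O`: 12500 nM
- Compound 3 `COc1cc(O)c2c(=O)cc(-c3ccccc3Cl)oc2c1CN1CCCCC1`: 63400 nM

With compound 2 at 12500 nM in the middle of the three numbers, compound 3 stands higher at 63400 nM and compound 1 lower at 1700 nM on the same scale.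

The next compound, compound 4 `COc1cc(OC)c(C(=O)/C=C/c2ccccc2Cl)c(O)c1CN(C)CCCN(C)C`, shares the core of compound 2 and changes only the chain on the amine (2-(dimethylamino)ethyl in place of carboxy on a saturated chain carbon bound to an amine nitrogen). Put simply, 2-(dimethylamino)ethyl comes in place of carboxy on a saturated chain carbon bound to an amine nitrogen.

Within the data shown here, one measured step bears on this change. Going to the carboxy-bearing compound 2 from the piperidin-1-yl compound cost activity (a 7.4-fold higher number from compound 1 to compound 2 (0.87 log units; beyond the scatter)). Compound 3 has another core and offers no comparison here. Compound 4, like compound 1, has no carboxy group, so a move back toward stronger inhibition in this assay seems likely. Among the measured compounds shown here, no measured compound carries this open chain, however, so the recovery may be only partial and the range stays wide.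

The expected change is a lower number of somewhat smaller size than the measured step (a 4.2-fold lower number from compound 2 to compound 4 (0.62 log units; beyond the scatter)).

For compound 4 the estimated value is 3000 nM with an expected range from 900 nM to 10000 nM in this read-out.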

Compound 4, half-maximal inhibitory concentration: 14500 nM
Compound 4: middle estimate off by 4.8-fold (0.68 log units), on the low side; the measured number lies above the stated range.
By their numbers in this assay, from the lowest: compound 1; then compounds 2 and 4 (each within the scatter of the next); then compound 3.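

In this assay, taking away the carboxy group does not by itself restore activity: with 2-(dimethylamino)ethyl in its place on a saturated chain carbon bound to an amine nitrogen, the two compounds cannot be told apart (a 1.2-fold higher number from compound 2 to compound 4 (0.06 log units; within the scatter)). The piperidin-1-yl compound stays clearly ahead of this new open-chain compound (an 8.5-fold higher number from compound 1 to compound 4 (0.93 log units; beyond the scatter)), so among compounds 1, 2 and 4 only the piperidin-1-yl group goes with the lower number, whether the open chain ends in carboxy or in dimethylamino. Nothing measured here explains why two such different chain ends give numbers within the usual scatter of each other.

The compounds shown leave open whether other ring amines, such as pyrrolidin-1-yl, morpholin-4-yl or piperazin-1-yl, would stay close to compound 1 at 1700 nM or fall back to the level of the open chains. They also leave open whether a shorter open chain ending in an amine would separate from compound 4, and whether any of these changes would act the same way on the core of compound 3.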